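From Fluoro to Phenyl: Estimating Compound 3

This account rests on a few compounds, and the source may have more. Where it says the series, first, only, none or still open, it means among the compounds named here.

Of the compounds shown here, two that share one core have been measured in an assay on microsomes for inhibition of 3-hydroxy-3-methylglutaryl-coenzyme A reductase (Rattus norvegicus); on this read-out higher numbers stand for weaker inhibition and lower numbers for stronger inhibition. Compound 1 `CC(C)c1sc(-c2ccccc2)c(C2CCCCC2)c1/C=C/[C@@H](O)C[C@@H](O)CC(=O)O` gives 202 nM in this assay, while compound 2 `CC(C)c1sc(-c2ccccc2)c(-c2ccc(F)cc2)c1/C=C/[C@@H](O)C[C@@H](O)CC(=O)O` gives 4.4 nM. Among the compounds with values here, the single measured step, a 46-fold lower number from compound 1 to compound 2 (1.66 log units; beyond the scatter), is the only comparison available, and it leaves compound 2 with the lowest number of the two. Compound 3 `CC(C)c1sc(-c2ccccc2)c(-c2ccc(-c3ccccc3)cc2)c1/C=C/[C@@H](O)C[C@@H](O)CC(=O)O` differs from compound 2 by one change: phenyl in place of fluoro on an aromatic carbon. Within the data shown here, no measured step concerns this exact change; the step from compound 1 to compound 2 replaces the whole group on that carbon and says nothing about extending the group already present in compound 2. Among the measured compounds shown here, with only that indirect guide, the step from compound 2 to compound 3 is expected to be a 4.5-fold higher number from compound 2 to compound 3 (0.66 log units; beyond the scatter), a moderate weakening beyond the scatter but far from the size of the measured step. Compound 3 is therefore expected to give about 20 nM, within a range from 4 nM to 100 nM.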

Compound 3, half-maximal inhibitory concentration: > 10000 nM
Compound 3 was reported as a limit; the forecaster's own chance of this, stated with the estimate: 2%; middle value at least 500-fold (2.69 log units) from the limit.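

Compound 3 is reported only as a limit of the assay, not as a number: the limit of > 10000 nM in this assay, at which 1 of the 3 values shown sits.

Even so, the position proves highly sensitive to what stands on the outer end of its aromatic ring: putting phenyl in place of fluoro gives an at least 2200-fold higher number from compound 2 to compound 3 (3.35 log units; beyond the scatter), a step larger than any the earlier compounds showed. An aromatic ring on this carbon is therefore not enough in itself, since 4-phenylphenyl in place of cyclohexyl gives an at least 49-fold higher number from compound 1 to compound 3 (1.69 log units; beyond the scatter), the opposite direction to the step made by 4-fluorophenyl.

The compounds shown cannot tell whether a group of intermediate size at this spot on the ring, such as chloro, methyl or methoxy, keeps the low number of 4-fluorophenyl or already loses it. They also give no reason for the loss.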